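The compounds below may be only part of what the source reports. "The series", "measured", "known", "first", "only" and "open" are said of these compounds alone.

Working notes on the series. In an ADME assay on Huh-7 cells (Homo sapiens) for cytotoxicity (on this read-out lower numbers stand for higher toxicity in this test and higher numbers for lower toxicity in this test), compound 1 `CN1CCN(CCCNCc2cn(-c3ccc(C(F)(F)F)cc3)nc2-c2ccc(OC(F)(F)F)cc2)CC1` gives 2300 nM. Compound 2 `Cc1ccccc1CNc1nn(-c2ccc(F)cc2F)cc1CNCCN1CCN(C)CC1` gives only a limit in this assay, > 20000 nM. Compound 3 `Cc1ccccc1-c1nn(-c2ccc(F)cc2F)cc1CNCCN(C)C` likewise returns a limit in this assay, > 20000 nM. Compound 2 therefore stands at the limit of > 20000 nM in this assay, at which 2 of the 3 values shown sit, so no number is known for it, only that it lies beyond the measured range. Compound 4 `Cc1ccc(-c2nn(-c3ccc(F)cc3F)cc2CNCCN2CCN(C)CC2)cc1` is not yet measured in this assay. It differs from compound 2 by 4-methylphenyl in place of (2-methylbenzyl)amino on an aromatic carbon. Among the compounds with values here, no step between measured compounds is known, so the size of this step has no precedent here. The expectation is a step from compound 2 to compound 4 of an at least 1.1-fold lower number from compound 2 to compound 4 (0.04 log units; that floor lies within the scatter), none beyond the scatter, because compound 2 sits at the limit of > 20000 nM in this assay, at which 2 of the 3 values shown sit. Compound 4 is estimated at 18000 nM, within 6000 nM to 50000 nM, most likely again reported as a limit.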

Compound 4, half-maximal cytotoxic concentration: > 20000 nM
Compound 4 ended at the assay's limit; the forecaster's own chance of this, stated with the estimate: 60%; at least 1.1-fold (0.04 log units) between middle value and limit.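

Compound 2 and compound 4 both end as limits in this assay, so no step between them can be read: the limit of > 20000 nM in this assay, at which 3 of the 4 values shown sit.

As far as these compounds go, whether 4-methylphenyl in place of (2-methylbenzyl)amino changes the half-maximal cytotoxic concentration at all stays open.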